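A few compounds are considered here, and "the series" means these few. Any claim that something is new, unique, unknown or untested is made for them only; others in the source may bear on it.

Compound 1 `CO[C@H]1CC[C@@H](Nc2cc(NCc3cnccc3C(F)(F)F)ncc2C#N)CC1` gives 5000 nM in an assay on isolated protein for inhibition of protein kinase C delta type (Homo sapiens), read by TR-FRET, with a stated time of 2 h; on this read-out higher numbers stand for weaker inhibition and lower numbers for stronger inhibition.
Compound 2 `N#Cc1cnc(NCc2cnccc2C(F)(F)F)cc1NC[C@H]1CC[C@H](O)CC1` gives 2000 nM in this assay.
Compound 3 `N#Cc1cnc(NCc2cnccc2C(F)(F)F)cc1NC1CCOCC1` gives 9800 nM in this assay.

Compound 1 holds the second highest of these three numbers. The step of a 2.0-fold higher number from compound 1 to compound 3 (0.29 log units; within the scatter) stays within the scatter, while a 2.5-fold lower number from compound 1 to compound 2 (0.40 log units; beyond the scatter) is a modest step beyond it. Compound 4 `N#Cc1cnc(NCc2cnccc2C(F)(F)F)cc1N[C@H]1CC[C@@H](n2cncn2)CC1` differs from compound 1 by 1H-1,2,4-triazol-1-yl in place of methoxy on a saturated ring carbon. Neither measured step puts an aromatic ring at this place, so they bear on the change only loosely: the two swaps on the nitrogen on the aromatic ring moved the number no more than modestly, one in each direction. A change of similar size at most, in either direction, is therefore expected for compound 4, with an estimate of 3500 nM (range 1000 nM to 12000 nM), which means an expected 1.4-fold lower number from compound 1 to compound 4 (0.15 log units; within the scatter).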

Compound 4, half-maximal inhibitory concentration: 5500 nM
Beside the measured number, compound 4's estimate is 1.6-fold (0.20 log units) below it; the range from low to high includes it.
By their numbers in this assay, from the lowest: compound 2; then compounds 1, 4 and 3 (each within the scatter of the next).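

Placing 1H-1,2,4-triazol-1-yl in place of methoxy gives a 1.1-fold higher number from compound 1 to compound 4 (0.04 log units; within the scatter) in this assay, so this saturated ring carbon accepts a five-membered aromatic ring with no difference that can be told from the scatter. The earlier steps shown here replaced the whole group on the nitrogen, whereas here the six-membered ring of carbon only stays and just the group on it differs. No available evidence explains this result. As far as these compounds go, whether an amine, a carboxylic acid or a longer chain at this place would shift the number remains open.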